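This account rests on a few compounds, and the source may have more. Where it says the series, first, only, none or still open, it means among the compounds named here.

Compound 1 `COc1ccc(NC(=O)C2CCc3ccccc3N2)cc1` and compound 2 `O=C(Nc1ccccc1)C1CCc2ccccc2N1` share one core and differ in a single aromatic substituent. In a functional assay on MDA-MB-231 cells (Homo sapiens) for cytotoxicity, read by sulforhodamine B assay, with a stated time of 72 h (on this read-out higher numbers stand for weaker inhibition of growth and lower numbers for stronger inhibition of growth), compound 1 gives 51400 nM and compound 2 gives 108000 nM; the step of a 2.1-fold higher number from compound 1 to compound 2 (0.32 log units; beyond the scatter) leaves compound 2 at the higher of the two numbers. Compound 3 `O=C(Nc1ccccc1O)C1CCc2ccccc2N1` follows from compound 2 by hydroxy in place of hydrogen on an aromatic carbon. Going by the values given here, the only step that bears on it is a 2.1-fold higher number from compound 1 to compound 2 (0.32 log units; beyond the scatter), a modest rise on loss of methoxy, so a modest fall or none beyond the scatter is expected here, the expected step being a 1.5-fold lower number from compound 2 to compound 3 (0.19 log units; within the scatter). Compound 3 is therefore estimated at 70000 nM in this assay, within 25000 nM to 200000 nM.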

Compound 3, concentration for 50% growth inhibition: 5260 nM
Estimate against measurement, compound 3: 13-fold (1.12 log units) above, outside the stated range (below it).
By their numbers in this assay, from the lowest: compound 3; then compound 1; then compound 2.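

On the aromatic carbon ortho to a large group, hydroxy in place of hydrogen gives, in this assay, a 21-fold lower number from compound 2 to compound 3 (1.31 log units; beyond the scatter). That single hydroxy thus moves the number far more than the modest methoxy step did, so the size of a change in this series is not fixed by the earlier pair alone. No measurement here accounts for the size of this step.

Going by these compounds, whether the effect belongs to hydroxy or to any group at this place stays open. An amine or a methoxy on this same carbon would separate those readings.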